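A chloro to bromo swap on compound 2

This account rests on a few compounds, and the source may have more. Where it says the series, first, only, none or still open, it means among the compounds named here.

Compound 1 `CCOC(=O)c1c(-c2cccc(Br)c2)[nH]c2cc(OC)ccc2c1=O` gives > 21500 nM
Compound 2 `CCOC(=O)c1c(-c2cccc(Cl)c2)[nH]c2cc(OC)c(Cl)cc2c1=O` gives > 21500 nM

These entries come from an ADME assay on Raji cells (Homo sapiens) for cytotoxicity, read by luminescence, with a stated time of 72 h (on this read-out lower numbers stand for an effect already at smaller amounts and higher numbers for an effect only at larger amounts of compound), and neither is a number. Compound 2 stands at the limit of > 21500 nM, so only a limit is known for it. The wider picture is equally thin, with the limit of > 21500 nM in this assay, at which 2 of the 2 values shown sit.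

Compound 3 `CCOC(=O)c1c(-c2cccc(Br)c2)[nH]c2cc(OC)c(Cl)cc2c1=O` has not yet been measured. It differs from compound 2 by bromo in place of chloro on an aromatic carbon, so that 3-chlorophenyl becomes 3-bromophenyl. Within the data shown here, no step between measured compounds is available to size this change. No shift beyond the scatter is therefore expected in this assay, and a further limit is the likeliest report. The expected change is a step that the limit leaves unreadable from compound 2 to compound 3. The estimate for compound 3 is 22000 nM, with an expected range from 9000 nM to 50000 nM.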

Compound 3, half-maximal effective concentration: > 21500 nM
Compound 3: a limit, no number (the forecaster's own chance of this, stated with the estimate: 75%); the middle value lies beyond the limit too.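

In this assay compound 3 gives > 21500 nM, a limit and not a number. Among these compounds, no step from compound 1 or compound 2 to compound 3 can be read. The compounds shown leave open whether 3-chlorophenyl and 3-bromophenyl differ here, and where any of the three would give a number.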